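Swapping a propanoylamino for fluoro on the outer ring

This account rests on a few compounds, and the source may have more. Where it says the series, first, only, none or still open, it means among the compounds named here.

Measured so far:
compound 1 `O=C1N=C(c2ccc(Cl)cc2)S/C1=C\c1cccc(Oc2ccccc2)c1` gives 320 nM
compound 2 `COc1ccc(/C=C2\SC(c3ccc(NC(=O)CCc4ccccc4)cc3)=NC2=O)cc1` gives 260 nM
compound 3 `CCC(=O)Nc1ccc(C2=NC(=O)/C(=C/c3ccc(OC)cc3)S2)cc1` gives 1840 nM

All three compounds share one core and were tested in an assay on cells for inhibition of Polyunsaturated fatty acid 5-lipoxygenase (Homo sapiens), read by HPLC, with stated times of 15 min and 10 min; on this read-out higher numbers stand for weaker inhibition and lower numbers for stronger inhibition. Compound 3 carries the highest number of the three, standing beyond the scatter from both compound 1 and compound 2. For the measured compounds named here, the only single-point change measured within this group is a 7.1-fold higher number from compound 2 to compound 3 (0.85 log units; beyond the scatter), which shows that trimming the side chain on the outer ring costs a modest amount of inhibition.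

Compound 4 `COc1ccc(/C=C2\SC(c3ccc(F)cc3)=NC2=O)cc1` is the next, unmeasured member. It differs from compound 3 by fluoro in place of propanoylamino on an aromatic carbon, the substituent sitting on an aromatic carbon of a six-membered aromatic ring of carbon only, para to a large group. Going by the values given here, no measured step covers this exchange directly. The closest point of comparison is compound 1, which carries a halogen on the same ring, though its other ring also differs, so it bears on the question only loosely. Because compound 1 gives 320 nM while compound 3 gives 1840 nM, a halogen in this position appears compatible with a lower number than that of compound 3. Compound 4 is therefore expected to move by a 3.3-fold lower number from compound 3 to compound 4 (0.52 log units; beyond the scatter), toward a stronger result. The estimate for compound 4 is 550 nM, with a range from 180 nM to 1700 nM.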

Compound 4, half-maximal inhibitory concentration: 200 nM
For compound 4 the middle estimate is 2.8-fold (0.44 log units) above the measured one; low and high end bracket the measured number.
By their numbers in this assay, from the lowest: compounds 4, 2 and 1 (each within the scatter of the next); then compound 3.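

The earlier step from compound 2 to compound 3 kept the amide and changed only the end of the chain, whereas this exchange removes the whole propanoylamino from the aromatic carbon, amide hydrogen and carbonyl included, and gives a 9.2-fold lower number from compound 3 to compound 4 (0.96 log units; beyond the scatter). The amide is therefore not needed for a low number at this place, since a single fluoro serves at least as well as the propanoylamino. Compound 4 at 200 nM and compound 2 at 260 nM lie within the usual scatter of each other, so the number does not simply follow the size of the group here: fluoro and the much longer phenyl-ended chain read alike, and the propanoylamino of compound 3 alone stands apart.

Nothing available explains why the propanoylamino stands apart. The compounds shown also leave open whether fluoro is special or whether other groups on this aromatic carbon, such as a methyl, an amine or a carboxylic acid, would give a similarly low number on the same core.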